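The source may report more compounds than this note shows. Statements on the series, on what has been measured and on what is new or still open speak of the compounds shown alone.

The measured compounds, in a functional assay on MCF7 cells (Homo sapiens) for inhibition, read by MTT assay, with a stated time of 48 h; a lower number here means a stronger inhibitor, a higher number a weaker inhibitor:

Compound 1 `COc1cc(N(Cc2nc3ccccc3[nH]2)S(=O)(=O)c2ccccc2)cc(OC)c1OC`: 27300 nM
Compound 2 `COc1cc(N(Cc2nc3ccccc3[nH]2)S(=O)(=O)c2ccccc2Cl)cc(OC)c1OC`: 38100 nM
Compound 3 `COc1cc(N(Cc2nc3ccccc3[nH]2)C(=O)c2ccc(F)cc2)cc(OC)c1OC`: 45200 nM

Compound 3 sits among three numbers that are all within the scatter of one another: the step of a 1.7-fold higher number from compound 1 to compound 3 (0.22 log units; within the scatter) and the step of a 1.2-fold higher number from compound 2 to compound 3 (0.07 log units; within the scatter) are both too small to set any compound apart, as is the step of a 1.4-fold higher number from compound 1 to compound 2 (0.14 log units; within the scatter) between the other two. Compound 4 `COc1ccc(C(=O)N(Cc2nc3ccccc3[nH]2)c2cc(OC)c(OC)c(OC)c2)cc1OC` is the compound not yet measured. It differs from compound 3 in one place, (3,4-dimethoxyphenyl in place of 4-fluorophenyl on a carbonyl carbon), the 3,4-dimethoxyphenyl bringing two hydrogen-bond acceptors where the 4-fluorophenyl had none.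

Going by the values given here, no measured step changes the group on the carbonyl carbon, so none bears on it directly. What the measured steps do show is that changing the group attached to the nitrogen, whether by a chloro on its aromatic ring or by exchanging a phenylsulfonyl for a (4-fluorophenyl)carbonyl, left the number within the scatter each time. On that basis compound 4 is expected to stay near compound 3, with a step of a 1.1-fold lower number from compound 3 to compound 4 (0.05 log units; within the scatter) in this assay that is expected to fall within the scatter. Compound 4 is therefore estimated at 40000 nM, with a range from 15000 nM to 110000 nM.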

Compound 4, half-maximal inhibitory concentration: > 50000 nM
Compound 4: no number, only a limit (the forecaster's own chance of this, stated with the estimate: 12%); at least 1.2-fold (0.09 log units) between middle value and limit.
By their numbers in this assay, from the lowest: compounds 1, 2 and 3 (each within the scatter of the next). At a limit, above all of these: compound 4.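

Compound 4 gives no number in this assay, only a limit of the assay: the limit of > 50000 nM in this assay, at which 1 of the 4 values shown sits.

This is the only change shown on the carbonyl carbon, and the step, an at least 1.1-fold higher number from compound 3 to compound 4 (0.04 log units; that floor lies within the scatter), gives a floor alone, so the true size of the change cannot be read and no shift is established. What the position does show is that placing 3,4-dimethoxyphenyl there, with its 2 hydrogen-bond acceptors where 4-fluorophenyl had 0, did not yield a measurable value within the range of this test, so the added acceptors brought no detectable gain.

The compounds shown leave open how a phenyl carrying an amine or a carboxylic acid would read in this assay if it stood in place of the 3,4-dimethoxyphenyl on the carbonyl carbon. They also leave open whether a phenyl with a single methoxy group at that place would return a number rather than a limit, and so whether one methoxy group or both are tied to this outcome.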